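The compounds below may be only part of what the source reports. "The series", "measured", "known", "first", "only" and "open" are said of these compounds alone.

Measured compounds in a functional assay on the whole organism (artery, strain albino) with Rattus norvegicus as the target, with a stated time of 300 min, at a dose of 10 mg/kg by the oral route; on this read-out lower numbers stand for less inhibition and higher numbers for more inhibition at the one dose given (going by the name of the read-out):
Compound 1 `CC1=C(C(=O)Nc2ccc(F)cc2)C(c2ccc([N+](=O)[O-])cc2)N=C(SCc2ccccc2)N1` gives 38.5%.
Compound 2 `CC1=C(C(=O)Nc2ccc(Br)cc2)C(c2ccc(Cl)cc2Cl)N=C(SCc2ccccc2)N1` gives 22.1%.
Compound 3 `COc1ccc(C2N=C(SCc3ccccc3)NC(C)=C2C(=O)Nc2ccc(Br)cc2)cc1` gives 16.4%.

Compound 3 stands at the low end of these three numbers. Its nearest neighbour is compound 2, and the two lie within the scatter of each other, so no order between them can be read. Compound 1 sits beyond the scatter above compound 3. For the measured compounds named here, the one step measured between neighbours, a number 5.7 percentage points lower from compound 2 to compound 3 (within the scatter), exchanges the aryl group on the saturated ring carbon and stays within the scatter.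

Compound 4 `COc1ccc(C2N=C(SCc3ccc(Cl)cc3)NC(C)=C2C(=O)Nc2ccc(Br)cc2)cc1` differs from compound 3 at another place: chloro in place of hydrogen on an aromatic carbon. Chloro replaces hydrogen on a six-membered aromatic ring of carbon only, para to a large group, so that benzylsulfanyl becomes (4-chlorobenzyl)sulfanyl. Going by the values given here, none of the measured steps touches this part of the core, so no measured step bears directly on it. Among the compounds with values here, the only step measured, on a different aryl group, was within the scatter. In this assay, compound 4 is therefore expected to show a step of a number 1.6 percentage points higher from compound 3 to compound 4 (within the scatter), that is, none beyond the scatter. Compound 4 is estimated at 18%, with a range from 6% to 32%.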

Compound 4, a percentage reported as inhibition, in the whole organism at one dose (the size of the read-out at that dose, not a potency): 37.9%
The estimate for compound 4 lay 19.9 percentage points below the measured number; the whole stated range lies below it.
By their numbers in this assay, from the lowest: compounds 3 and 2 (each within the scatter of the next); then compounds 4 and 1 (each within the scatter of the next).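

In this assay the phenyl ring of the benzylsulfanyl group proves to be a place where one added atom can shift the number: the change to (4-chlorobenzyl)sulfanyl gives a number 21.5 percentage points higher from compound 3 to compound 4 (beyond the scatter) and so stands clear of the usual variation. The only earlier step, a number 5.7 percentage points lower from compound 2 to compound 3 (within the scatter), exchanged the aryl group on the saturated ring carbon and could not be told apart from that variation, so this is the first single change among these compounds that can be read as a real difference. Nothing shown here explains why chloro on this aromatic carbon, para to a large group, has this effect, and no supporting measurement bears on it.

The compounds shown leave open whether a fluoro, a methoxy or a nitro group at the same place would move the number as chloro does, and whether a longer chain in place of benzyl would keep the gain. They also leave open whether the same chloro step would hold with the 2,4-dichlorophenyl group of compound 2 on the saturated ring carbon, since it is seen here with a single 4-methoxyphenyl partner only.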